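This account rests on a few compounds, and the source may have more. Where it says the series, first, only, none or still open, it means among the compounds named here.

Compound 1, `O=C(NCc1ccccc1)c1csc(-c2c[nH]c3ccccc23)n1`, in a functional assay on LNCaP C4-2 cells (Homo sapiens) for cytotoxicity, read by MTT assay, with a stated time of 48 h, in the absence of a further agent (on this read-out lower numbers stand for stronger inhibition and higher numbers for weaker inhibition), reaches only the assay's limit, > 100000 nM.
Compound 2, `COc1ccc(NC(=O)c2csc(-c3cn(Cc4ccc(Cl)cc4)c4ccccc34)n2)cc1`, in this assay likewise reaches only the limit, > 100000 nM.
Compound 3, `O=C(Nc1ccccc1)c1csc(-c2cn(Cc3ccc(Cl)cc3)c3ccccc23)n1`, in this assay also reaches only the limit, > 100000 nM.

Compound 3 therefore stands at the same limit as the two other measured compounds; on these numbers nothing separates any of them, and none can be called stronger or weaker than another. For the measured compounds named here, the only measured step between neighbours, a step that the two limits leave unreadable from compound 2 to compound 3, cannot be given a size, since both of its ends sit at the limit (the limit of > 100000 nM in this assay, at which 3 of the 3 values shown sit).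

The change to compound 4, `O=C(Nc1ccccc1)c1csc(-c2c[nH]c3ccccc23)n1`, is hydrogen in place of 4-chlorobenzyl on an aromatic nitrogen. Going by the values given here, no measured pair shows this same change, so no step is available to set its size. Compound 1 already carries the bare ring nitrogen, with a different amide, and sits at the limit, which is at least consistent with the bare ring nitrogen giving no measurable inhibition.

On this basis the step that the limit leaves unreadable from compound 3 to compound 4 is expected to be none that the assay can register, with compound 4 again expected to be reported only as a limit. The estimate for compound 4 in this assay is 150000 nM, with a range from 50000 nM to 500000 nM.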

Compound 4, half-maximal inhibitory concentration: > 100000 nM
Compound 4 ended at the assay's limit; the forecaster's own chance of this, stated with the estimate: 85%; the middle value does not contradict the limit.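

Neither the step from compound 3 to compound 4 nor the step from compound 1 to compound 4 can be read, because both ends of each are limits rather than numbers: the limit of > 100000 nM in this assay, at which 4 of the 4 values shown sit.

The compounds shown leave open whether hydrogen or 4-chlorobenzyl on the aromatic nitrogen, or phenyl or benzyl on the amide-type nitrogen, makes any difference to cytotoxicity.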